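Swapping Phenethyl for Thiophen-2-yl on the Amide Carbonyl

The source may hold more compounds than are shown below. What is called first, only, known or untested is meant among the compounds shown, and "the series" means these compounds.

In a functional assay on A549 cells (Homo sapiens) for inhibition, read by MTT assay, with a stated time of 48 h (on this read-out higher numbers stand for weaker inhibition and lower numbers for stronger inhibition), compound 2 `O=C(CCc1ccccc1)Nc1ccc(N2CCN(c3ccc(OC[C@@H]4CO[C@@](Cn5cncn5)(c5ccc(Cl)cc5Cl)O4)cc3)CC2)cc1` gives 2060 nM, the smallest number among the three measured compounds. Compound 1 `CCC(=O)Nc1ccc(N2CCN(c3ccc(OC[C@@H]4CO[C@@](Cn5cncn5)(c5ccc(Cl)cc5Cl)O4)cc3)CC2)cc1` gives 2550 nM, and a 1.2-fold lower number from compound 1 to compound 2 (0.09 log units; within the scatter), so these two cannot be told apart. Compound 3 `O=C(Nc1ccc(N2CCN(c3ccc(OC[C@@H]4CO[C@@](Cn5cncn5)(c5ccc(Cl)cc5Cl)O4)cc3)CC2)cc1)c1cccc(F)c1` gives 6640 nM. The change to compound 4 `O=C(Nc1ccc(N2CCN(c3ccc(OC[C@@H]4CO[C@@](Cn5cncn5)(c5ccc(Cl)cc5Cl)O4)cc3)CC2)cc1)c1cccs1` is thiophen-2-yl in place of phenethyl on a carbonyl carbon. For the measured compounds named here, the steps that bear on it both place an aromatic ring on the carbonyl carbon: a 2.6-fold higher number from compound 1 to compound 3 (0.42 log units; beyond the scatter) and a 3.2-fold higher number from compound 2 to compound 3 (0.51 log units; beyond the scatter). Compound 4 likewise carries an aromatic ring on the carbonyl carbon, so a modestly higher number is expected, a 2.4-fold higher number from compound 2 to compound 4 (0.39 log units; beyond the scatter), because of a 3.2-fold higher number from compound 2 to compound 3 (0.51 log units; beyond the scatter). Compound 4 is therefore estimated at 5000 nM, within a range from 2500 nM to 10000 nM.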

Compound 4, half-maximal inhibitory concentration: 4330 nM
Compound 4: the middle estimate sits 1.2-fold (0.06 log units) above what was measured, within the range that was stated.
By their numbers in this assay, from the lowest: compounds 2, 1, 4 and 3 (each within the scatter of the next, the first and the last beyond it).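

A second aromatic group set directly on the carbonyl carbon also departs from phenethyl, with a 2.1-fold higher number from compound 2 to compound 4 (0.32 log units; beyond the scatter) as the step, so this shift is not confined to 3-fluorophenyl. Thiophen-2-yl cannot be told apart from 3-fluorophenyl, given a 1.5-fold lower number from compound 3 to compound 4 (0.19 log units; within the scatter) as the step, nor from ethyl, given a 1.7-fold higher number from compound 1 to compound 4 (0.23 log units; within the scatter) as the step. Nothing available explains these steps. Still open, as far as these compounds go, is how a saturated ring such as cyclohexyl, or an amine or carboxylic acid carried on the chain, would read at this carbonyl carbon.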